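The compounds below may be only part of what the source reports. "The series", "measured", "known", "first", "only" and "open" are said of these compounds alone.

Compound 1, `CC(O)(C#Cc1ccc(N2CCNCC2)c(Nc2ncnc3[nH]ccc23)c1)c1nccs1`, is the starting point. In an assay for inhibition of mitogen-activated protein kinase kinase kinase 14 (Homo sapiens), read by luminescence and ADP-Glo, with a stated time of 120 min, in the presence of a further agent that is not named here (on this read-out lower numbers stand for stronger inhibition and higher numbers for weaker inhibition), compound 1 gives 47.9 nM. Two close relatives carry a small alkyl group on the ring amine nitrogen where compound 1 carries hydrogen. Compound 2, `CN1CCN(c2ccc(C#CC(C)(O)c3nccs3)cc2Nc2ncnc3[nH]ccc23)CC1`, gives 78.3 nM, and compound 3, `CCN1CCN(c2ccc(C#CC(C)(O)c3nccs3)cc2Nc2ncnc3[nH]ccc23)CC1`, gives 34.5 nM. Among the three numbers, that of compound 1 lies nearest to compound 3 and furthest from compound 2, and both gaps are within the scatter: the step of a 1.6-fold higher number from compound 1 to compound 2 (0.21 log units; within the scatter) and the step of a 1.4-fold lower number from compound 1 to compound 3 (0.14 log units; within the scatter) each stay inside it, so neither a methyl nor an ethyl group at that nitrogen moved the number in a way that can be trusted.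

Compound 4, `CCS(=O)(=O)N1CCN(c2ccc(C#CC(C)(O)c3nccs3)cc2Nc2ncnc3[nH]ccc23)CC1`, alters the same position: ethylsulfonyl in place of hydrogen on an amine nitrogen in a ring. For the measured compounds named here, no measured step here places a group of this kind on that nitrogen; the two measured steps at the same place were methyl and ethyl. Because a 1.6-fold higher number from compound 1 to compound 2 (0.21 log units; within the scatter) and a 1.4-fold lower number from compound 1 to compound 3 (0.14 log units; within the scatter) were both within the scatter, a change at this nitrogen is expected to leave the number roughly where it was, with some room for a somewhat weaker result. Compound 4 is therefore estimated at 65 nM, within a range from 20 nM to 200 nM, which means an expected step of a 1.4-fold higher number from compound 1 to compound 4 (0.13 log units; within the scatter).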

Compound 4, half-maximal inhibitory concentration: 8.22 nM
The estimate for compound 4 lay 7.9-fold (0.90 log units) above the measured number; measured number below the stated range.
By their numbers in this assay, from the lowest: compound 4; then compounds 3, 1 and 2 (each within the scatter of the next, the first and the last beyond it).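

The amine nitrogen of the piperazin-1-yl group is not a place where every change leaves the number alone: in this assay, ethylsulfonyl in place of hydrogen gives a 5.8-fold lower number from compound 1 to compound 4 (0.77 log units; beyond the scatter), and this step lies beyond the scatter, unlike the steps to methyl or ethyl. The change also stands apart from the two small alkyl groups, with a 4.2-fold lower number from compound 3 to compound 4 (0.62 log units; beyond the scatter) and a 9.5-fold lower number from compound 2 to compound 4 (0.98 log units; beyond the scatter), so among the four groups seen at this nitrogen, ethylsulfonyl gives the lowest number. The earlier compounds shown here showed only that hydrogen and each alkyl group give similar numbers, while compound 4 shows that this nitrogen can carry a group of 5 heavy atoms with two double bonds outside aromatic rings and still give a lower number, which means stronger inhibition on this read-out.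

Nothing at hand says why the number falls with this group. As far as these compounds go, whether the sulfonyl part or the ethyl part matters stays open, as does whether methylsulfonyl, a longer chain on the sulfur, or an acetyl group on this nitrogen would give a similar number.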